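Swapping a Benzyl for an Aryl Ring on Compound 3

The source may report more compounds than this note shows. Statements on the series, on what has been measured and on what is new or still open speak of the compounds shown alone.

Compound 3 `COc1ccc(F)cc1CNCCCNc1ccnc2cc(Cc3cccc(C(F)(F)F)c3)ccc12` gives 23 10^-6 cm/s in an ADME assay for permeability, using PAMPA, with a stated time of 30 min, at pH 7.4; a higher number here means that the compound crosses the layer faster, a lower number that the compound crosses the layer more slowly. That places compound 3 level with compound 1 `CCC(CC)c1ccc2c(NCCCNCc3cc(F)ccc3OC)ccnc2c1`, which gives 23 10^-6 cm/s, and these two sit together at the bottom of the three measured numbers. Compound 2 `CC(C)(C)c1ccc(-c2ccc3c(NCCCNCc4ccco4)ccnc3c2)cc1` gives 237 10^-6 cm/s in this assay. Compound 4 `COc1ccc(F)cc1CNCCCNc1ccnc2cc(-c3ccc(C(C)(C)C)cc3)ccc12` differs from compound 3 by 4-(tert-butyl)phenyl in place of 3-(trifluoromethyl)benzyl on an aromatic carbon. Among the compounds with values here, the only measured step, no change at the digits printed from compound 1 to compound 3 (within the scatter), exchanged a group at this same aromatic carbon and left the reading unchanged, so it offers no direction on its own. Compound 2, however, carries the same 4-(tert-butyl)phenyl group and gives 237 10^-6 cm/s in this assay, well apart from compound 3. The expected step of a 5.2-fold higher number from compound 3 to compound 4 (0.72 log units; beyond the scatter) is therefore a rise beyond the scatter. Compound 4 is estimated at 120 10^-6 cm/s, with a range from 40 10^-6 cm/s to 300 10^-6 cm/s.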

Compound 4, apparent permeability: 237 10^-6 cm/s
Estimate against measurement, compound 4: 2.0-fold (0.30 log units) below, within the range that was stated.
By their numbers in this assay, from the lowest: compounds 1 and 3 (each within the scatter of the next); then compounds 2 and 4 (each within the scatter of the next).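

At this aromatic carbon the group matters in this assay, with 4-(tert-butyl)phenyl giving a 10-fold higher number from compound 3 to compound 4 (1.01 log units; beyond the scatter) and a 10-fold higher number from compound 1 to compound 4 (1.01 log units; beyond the scatter) where the earlier exchange there changed nothing. With 4-(tert-butyl)phenyl in place, 5-fluoro-2-methoxyphenyl in place of furan-2-yl on the saturated chain carbon gives no change at the digits printed from compound 2 to compound 4 (within the scatter) as its result. No measurement shown explains these steps. The step from compound 3 to compound 4 swaps the benzyl for a phenyl and the trifluoromethyl for a tert-butyl together, and the compounds shown do not separate the two. On these data alone, how a plain phenyl or a phenyl carrying a carboxylic acid would read at this carbon stays open.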